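This account rests on a few compounds, and the source may have more. Where it says the series, first, only, none or still open, it means among the compounds named here.

Measured compounds:
compound 1 `CC(C)C(=O)OCCc1c(-c2ccccc2Cl)c2cc(Cl)ccc2[nH]c1=O` — 62000 nM
compound 2 `CCCCC(=O)OCCc1c(-c2ccccc2Cl)c2cc(Cl)ccc2[nH]c1=O` — 200000 nM
compound 3 `COCC(=O)OCCc1c(-c2ccccc2Cl)c2cc(Cl)ccc2[nH]c1=O` — 74000 nM

In an ADME assay on HepG2 2.2.15 cells (Homo sapiens) for cytotoxicity (a higher number here means that more compound is tolerated, a lower number that less compound is tolerated), compound 2 stands highest of the three, with compound 3 nearest at a 2.7-fold lower number from compound 2 to compound 3 (0.43 log units; beyond the scatter) and compound 1 furthest at a 3.2-fold higher number from compound 1 to compound 2 (0.51 log units; beyond the scatter); both steps lie beyond the scatter, so compound 2 tolerates the most. Compound 4 `O=C(CN1C(=O)c2ccccc2C1=O)OCCc1c(-c2ccccc2Cl)c2cc(Cl)ccc2[nH]c1=O` keeps the shared core and differs from compound 2 in one place: a group of 11 heavy atoms (8 carbon, 1 nitrogen, 2 oxygen; one five-membered non-aromatic ring with 1 hetero atom, one six-membered aromatic ring of carbon only) in place of a group of 3 heavy atoms (3 carbon; no ring), on a saturated chain carbon bound to a carbonyl carbon. Going by the values given here, the steps that bear on this are the two that touch the same ester side chain: from compound 1 to compound 2 the number rose modestly, and from compound 2 to compound 3 it fell modestly when methoxy replaced propyl at the same saturated chain carbon. Since the change in compound 4 is larger than either, the number is expected to move, most likely downward, away from the high value of compound 2. The estimate for compound 4 is 90000 nM, within 30000 nM to 250000 nM, which would mean an expected step of a 2.2-fold lower number from compound 2 to compound 4 (0.35 log units; beyond the scatter).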

Compound 4, half-maximal cytotoxic concentration: 960000 nM
Estimate against measurement, compound 4: 11-fold (1.03 log units) below; measured number above the stated range.
By their numbers in this assay, from the lowest: compounds 1 and 3 (each within the scatter of the next); then compound 2; then compound 4.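

In this assay compound 4 stands highest of the four, with a 4.8-fold higher number from compound 2 to compound 4 (0.68 log units; beyond the scatter) and the larger 13-fold higher number from compound 3 to compound 4 (1.11 log units; beyond the scatter) and a 15-fold higher number from compound 1 to compound 4 (1.19 log units; beyond the scatter) all pointing the same way. The earlier changes, among groups without a ring, were modest or within the scatter, whereas this position on a saturated chain carbon bound to a carbonyl carbon also takes a group of 11 heavy atoms with a five-membered non-aromatic ring and a six-membered aromatic ring, and more compound is tolerated. Nothing available explains this rise.

Going by these compounds, whether a plain phenyl, an amine or a carboxylic acid on the same carbon would give a number like that of compound 4 remains open. So does whether the number follows the size of the group or something specific to this one.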